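From butyl to 4-bromophenyl on a weakly active compound

The source may report more compounds than this note shows. Statements on the series, on what has been measured and on what is new or still open speak of the compounds shown alone.

Measured so far in a functional assay on L02 cells (Homo sapiens) for inhibition, read by Griess assay, with stated times of 1 h and 24 h; a lower number here means a stronger inhibitor, a higher number a weaker inhibitor
- compound 1 `CCCc1nn(C)c2c(NC(C)C)nc(/C=C/c3cccnc3)nc12` gives 574000 nM
- compound 2 `CCCc1nn(C)c2c(NC(C)C)nc(/C=C/c3ccc[n+]([O-])c3)nc12` gives 324000 nM
- compound 3 `CCCCNc1nc(/C=C/c2ccccc2)nc2ccsc12` gives > 1000000 nM (a limit, not a number)

Compound 3 stands at a limit, as the limit of > 1000000 nM in this assay, at which 1 of the 3 values shown sits, shows. Compound 4 `Brc1ccc(Nc2nc(/C=C/c3ccccc3)nc3ccsc23)cc1` differs from it by 4-bromophenyl in place of butyl on a nitrogen on an aromatic ring, with 4-bromophenyl in place of butyl on a nitrogen on an aromatic ring. Among the measured compounds shown here, the only measured step, a 1.8-fold lower number from compound 1 to compound 2 (0.25 log units; within the scatter), lies within the scatter and concerns a different change on a different core, so it offers no direct guide. With compound 1 at 574000 nM and compound 2 at 324000 nM, only a modest move towards a lower number is expected. The expected step is an at least 1.4-fold lower number from compound 3 to compound 4 (0.15 log units; that floor lies within the scatter) in this assay. The estimate for compound 4 is 700000 nM, with an expected range from 200000 nM to 2000000 nM.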

Compound 4, half-maximal inhibitory concentration: > 1000000 nM
Compound 4: no number, only a limit; the forecaster's own chance of this, stated with the estimate: 45%; middle value at least 1.4-fold (0.15 log units) from the limit.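

Compound 3 and compound 4 both stand at a limit rather than a number, so no step between them can be read: the limit of > 1000000 nM in this assay, at which 2 of the 4 values shown sit.

As far as these compounds go, whether 4-bromophenyl in place of butyl changes inhibition in this assay stays open.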